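A few compounds are considered here, and "the series" means these few. Any claim that something is new, unique, unknown or untested is made for them only; others in the source may bear on it.

Working notes on the series. Compound 1 `Cc1ncc([N+](=O)[O-])n1CCSC(=S)N1CCC(=O)CC1` is tested in an ADME assay on HeLa cells (Homo sapiens) for cytotoxicity; a lower number here means a stronger inhibitor, a higher number a weaker inhibitor. For compound 1 the reading in this assay is a limit of the assay rather than a number, > 1000 ug/mL. Compound 2 `Cc1ncc([N+](=O)[O-])n1CCSC(=S)N1CCC(OS(C)(=O)=O)CC1` also returns a limit in this assay, > 1000 ug/mL. Both readings sit at the limit of > 1000 ug/mL in this assay, at which 2 of the 2 values shown sit, so compound 1 stands alongside compound 2 with no number to separate them.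

Compound 3 `Cc1ncc([N+](=O)[O-])n1CCSC(=S)N1CCCC(C)C1` is not yet measured in this assay. Its change from compound 1: 3-methylpiperidin-1-yl in place of 4-oxopiperidin-1-yl on a thiocarbonyl carbon. Among the measured compounds shown here, no measured step covers this change. The expected step in this assay is none beyond the scatter because both readings sit at the limit of > 1000 ug/mL in this assay, at which 2 of the 2 values shown sit. Compound 3 is expected to return 1000 ug/mL, with a range of 500 ug/mL to 2000 ug/mL. The expected step is a number no higher from compound 1 to compound 3 (the limit leaves the size open), and the most likely outcome is again a limit rather than a number.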

Compound 3, half-maximal inhibitory concentration: 170 ug/mL
Beside the measured number, compound 3's estimate is 5.9-fold (0.77 log units) above it, outside the stated range (below it).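

Among the compounds shown here, this position on the thiocarbonyl carbon is the first to separate compounds in this assay: 3-methylpiperidin-1-yl in place of 4-oxopiperidin-1-yl gives an at least 5.8-fold lower number from compound 1 to compound 3 (0.76 log units; beyond the scatter). The six-membered non-aromatic ring remains, so the substituents on that ring are enough to bring a reading off the limit, although the carbonyl leaves and the methyl enters in the same step and neither can be credited alone. The series therefore no longer sits wholly at the limit: the limit of > 1000 ug/mL in this assay, at which 2 of the 3 values shown sit.

Going by these compounds, it remains open whether the drop follows the loss of the carbonyl or the gain of the methyl, a question that an unsubstituted piperidin-1-yl would address. How a 4-methylpiperidin-1-yl, a morpholin-4-yl ring or an open-chain dialkylamine would read at this position is also unknown.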